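The source may report more compounds than this note shows. Statements on the series, on what has been measured and on what is new or still open speak of the compounds shown alone.

Compound 1 `CCCn1c(=O)c2[nH]c(-c3ccc(S(=O)(=O)N4CCN(c5ccc(Cl)cc5)CC4)cc3)nc2n(C)c1=O`: 39%
Compound 2 `CCCn1c(=O)[nH]c2nc(-c3ccc(S(=O)(=O)N4CCN(c5ccccc5Cl)CC4)cc3)[nH]c2c1=O`: 32%

In an assay on CHO cells for displacement of a labelled ligand from adenosine receptor A3 (Homo sapiens), read by scintillation counting, with a stated time of 45 min, tested at 1 uM, in the presence of a further agent that is not named here (a higher number here means more inhibition at the concentration tested (going by the name of the read-out), a lower number less inhibition), compound 1 gives 39%, and compound 2 gives 32%. Compound 2 has the lower of the two numbers, but the gap to compound 1 lies within the usual scatter of this kind of measurement, so the two cannot be told apart on these data.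

Compound 3 `CCCn1c(=O)[nH]c2nc(-c3ccc(S(=O)(=O)N4CCN(c5ccc(C)cc5)CC4)cc3)[nH]c2c1=O` differs from compound 2 in a single place: 4-methylphenyl in place of 2-chlorophenyl on an amine nitrogen in a ring. Among the compounds with values here, no measured pair shows a step of exactly this kind, so the effect of the change can only be estimated. Both measured compounds sit in the same modest band, and a swap of one small aryl group for another on the same ring nitrogen is expected to shift the reading in this assay little, if at all. The step from compound 2 to compound 3 is expected to be a number 2 percentage points higher from compound 2 to compound 3 (within the scatter), no larger than the scatter. Compound 3 is therefore expected to give 34%, with a likely range from 20% to 50%.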

Compound 3, a percentage reported as inhibition, at one concentration (the size of the read-out at that concentration, not a potency): 25%
Compound 3: the middle estimate sits 9 percentage points above what was measured, within the range that was stated.
By their numbers in this assay, from the lowest: compounds 3, 2 and 1 (each within the scatter of the next, the first and the last beyond it).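

In this assay, putting 4-methylphenyl in place of 2-chlorophenyl on this amine nitrogen in a ring gives a number 7 percentage points lower from compound 2 to compound 3 (within the scatter), the first step shown that changes a single place. On these data, this exchange of one aryl group for another cannot be told apart from no change at all, even though it alters both the substituent on the aromatic ring and its numbered place there. Nothing measured here offers an explanation for the reading.

Chlorine and methyl change together with their place on the ring, so what each contributes alone stays open, and 2-methylphenyl on the same nitrogen would separate the two. Going by these compounds, how a plain phenyl, or an aromatic ring bearing an amine or a carboxylic acid, would read at this position also remains open.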